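Changing the sulfonyl group of compound 3

A few compounds are considered here, and "the series" means these few. Any claim that something is new, unique, unknown or untested is made for them only; others in the source may bear on it.

Of the compounds shown here, three have been measured in an ADME assay on HEK-293T cells (Homo sapiens) for inhibition, read by CCK-8 assay, with a stated time of 48 h, tested at 20 uM; on this read-out higher numbers stand for more inhibition of growth at the one concentration tested and lower numbers for less inhibition of growth. Compound 1 `COc1ccc(S(=O)(=O)Oc2ccccc2/C=C(\C#N)C(=O)Nc2nnc(-c3cccs3)s2)cc1` gives 40%, compound 2 `Cc1ccc(S(=O)(=O)Oc2cccc(/C=C(\C#N)C(=O)Nc3nnc(-c4cccs4)s3)c2)cc1` gives 43% and compound 3 `COc1ccc(Cc2nnc(NC(=O)/C(C#N)=C/c3ccccc3OS(=O)(=O)c3ccc(OC)cc3)s2)cc1` gives 30%. Compound 3 therefore lies within the usual scatter of compound 1, while the gap up to compound 2 lies beyond it.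

Compound 4 `COc1ccc(Cc2nnc(NC(=O)/C(C#N)=C/c3ccccc3OS(=O)(=O)c3ccccc3[N+](=O)[O-])s2)cc1` keeps the structure of compound 3 except for one group: 2-nitrophenyl in place of 4-methoxyphenyl on a sulfonyl sulfur. Here, 2-nitrophenyl takes the place of 4-methoxyphenyl on a sulfonyl sulfur.

For the measured compounds named here, no measured step changes this group. Going by the values given here, the only single-place step, a number 10 percentage points lower from compound 1 to compound 3 (within the scatter), swaps 4-methoxybenzyl for thiophen-2-yl at a different place, so it gives only a rough sense of scale. With that one step as a guide, no change beyond the scatter is expected in this assay. The expected step is a number 2 percentage points higher from compound 3 to compound 4 (within the scatter). Compound 4 is estimated at 32%, with an expected range from 18% to 46%.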

Compound 4, percent growth inhibition at one concentration: 18%
For compound 4 the middle estimate is 14 percentage points above the measured one; the range from low to high includes it.
By their numbers in this assay, from the lowest: compound 4; then compounds 3, 1 and 2 (each within the scatter of the next, the first and the last beyond it).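

With 2-nitrophenyl in place of 4-methoxyphenyl on a sulfonyl sulfur, the read-out in this assay gives a number 12 percentage points lower from compound 3 to compound 4 (beyond the scatter) and so less inhibition of growth. For the compounds shown here, this is the first measured step at this position, and it shows that changing the aromatic group on the sulfonyl sulfur alone, with the rest of the molecule kept, can move the number by more than the usual scatter. No available measurement explains this drop.

A single step cannot separate the effect of the nitro group from that of the methoxy group's loss, or show how much the place of each group on the ring matters. From the compounds shown here alone, how an unsubstituted phenyl, a 4-nitrophenyl or a phenyl ring carrying an amine would read on this sulfonyl sulfur remains open.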